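Sulfonyl sulfur change: compound 2 to compound 3

The source may hold more compounds than are shown below. What is called first, only, known or untested is meant among the compounds shown, and "the series" means these compounds.

Among the compounds with values here, in a functional assay on MIA PaCa-2 cells (Homo sapiens) for inhibition, read by MTT assay, with a stated time of 3 days (on this read-out lower numbers stand for stronger inhibition and higher numbers for weaker inhibition), compound 2 `CC(C)c1noc(N2CCN(C(=O)[C@@H]3CCCN(S(=O)(=O)c4ccc(S(=O)(=O)NC(C)(C)C)cc4)C3)CC2)n1` gives 100 nM and holds the lower of the two numbers so far. Compound 1 `CCN(CC)S(=O)(=O)c1ccc(S(=O)(=O)N2CCC[C@@H](C(=O)NC3COC3)C2)cc1` gives 900 nM as the higher number, and that gap lies beyond the usual scatter.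

Compound 3 `CCN(CC)S(=O)(=O)c1ccc(S(=O)(=O)N2CCC[C@@H](C(=O)N3CCN(c4nc(C(C)C)no4)CC3)C2)cc1` has not yet been measured. It departs from compound 2 through diethylamino in place of (tert-butyl)amino on a sulfonyl sulfur with diethylamino in place of (tert-butyl)amino on a sulfonyl sulfur. Within the data shown here, no measured pair isolates this change, so any forecast is loose. Among the measured compounds, diethylamino on a sulfonyl sulfur occurs only in compound 1 at 900 nM and this offers a weak hint of direction.

In this assay, among the measured compounds shown here, a modest rise in the number is expected, close to the edge of the scatter, and no large step is anticipated. The expected step is a 1.8-fold higher number from compound 2 to compound 3 (0.26 log units; within the scatter) and it remains an estimate. For compound 3 the expected value is 180 nM with an estimated range of 50 nM to 600 nM for repeat measurements.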

Compound 3, half-maximal inhibitory concentration: 30 nM
Compound 3: the middle estimate sits 6.0-fold (0.78 log units) above what was measured; measured number below the stated range.
By their numbers in this assay, from the lowest: compound 3; then compound 2; then compound 1.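

In this assay, within the data shown here, this is the first matched pair, and it shows that the group on the sulfonyl sulfur matters: diethylamino in place of (tert-butyl)amino gives a 3.3-fold lower number from compound 2 to compound 3 (0.52 log units; beyond the scatter). The change removes the hydrogen-bond donor counted on (tert-butyl)amino, so that donor is not needed for a number at this level in this pair. Diethylamino alone does not set the number, since compound 1 carries the same group and gives 900 nM, whereas compound 3 gives 30 nM, and these two differ in the group on the carbonyl.
No measured evidence on hand accounts for the step.

This one pair cannot separate the loss of the amine hydrogen from the change in how the carbons are arranged on the nitrogen. Dimethylamino, pyrrolidin-1-yl or morpholin-4-yl on the sulfonyl sulfur, and N-methyl-tert-butylamino as the closest match to the (tert-butyl)amino group without its hydrogen, would help to separate these two changes.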